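This account rests on a few compounds, and the source may have more. Where it says the series, first, only, none or still open, it means among the compounds named here.

In a functional assay on SGC-7901 cells (Homo sapiens) for antiproliferative activity, read by MTT assay, with a stated time of 24 h (a higher number here means a weaker inhibitor, a lower number a stronger inhibitor), compound 1 `Cc1cccc(NNC(=O)c2ccc(NS(=O)(=O)c3cnc(O)nc3O)cc2)c1` reads > 20000 nM as a limit. Compound 2 `O=C(NNc1ccc(F)cc1)c1ccc(NS(=O)(=O)c2cnc(O)nc2O)cc1` reads > 20000 nM as a limit too. Compound 3 `Cc1cccc(NNC(=O)c2cccc(NS(=O)(=O)c3cnc(O)nc3O)c2)c1` reads > 20000 nM and so stands only at a limit. Compound 4 `O=C(NNC(=O)c1ccccc1Cl)c1cccc(NS(=O)(=O)c2cnc(O)nc2O)c1` carries (2-chlorophenyl)carbonyl in place of 3-methylphenyl on an amine nitrogen is the change. Going by the values given here, the one measured step that bears on this position is a step that the two limits leave unreadable from compound 1 to compound 2 and it gives no size. The record so far is the limit of > 20000 nM in this assay, at which 3 of the 3 values shown sit, and offers no sign of a direction. No shift beyond the scatter is therefore expected in this assay and the expected step is a step that the limit leaves unreadable from compound 3 to compound 4 as an estimate only. Compound 4 is estimated at 22000 nM with an expected range from 10000 nM to 45000 nM in all likelihood.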

Compound 4, half-maximal inhibitory concentration: 6070 nM
Estimate against measurement, compound 4: 3.6-fold (0.56 log units) above, and the stated range ends above it.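

Placing (2-chlorophenyl)carbonyl on the amine nitrogen in place of 3-methylphenyl gives an at least 3.2-fold lower number from compound 3 to compound 4 (0.51 log units; beyond the scatter) in this assay. Going by these compounds alone, this shows that the position can move the read-out, which the earlier compounds could not show, as the step between compound 1 and compound 2 cannot be read. Compound 4 alone gives a number rather than a limit: the limit of > 20000 nM in this assay, at which 3 of the 4 values shown sit.

The carbonyl and the chlorine enter together, and the compounds shown leave open which of them carries this step. On these data alone, how a benzoyl group without chlorine or a 2-chlorophenyl group without the carbonyl would read also remains open.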